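This account rests on a few compounds, and the source may have more. Where it says the series, first, only, none or still open, it means among the compounds named here.

In an ADME assay on L02 cells (Homo sapiens) for cytotoxicity, read by MTT assay, with a stated time of 48 h (a higher number here means a weaker inhibitor, a lower number a stronger inhibitor), compound 1 (`CC[C@@H](C)[C@H](NC(=O)c1ccc(C(CC)(CC)c2ccc(OCC(O)C(C)(C)C)c(C)c2)n1CC)C(=O)O`) gives 1400 nM, while compound 2 (`CCn1c(C(=O)Oc2ccc(CCO)cc2)ccc1C(CC)(CC)c1ccc(OCC(O)C(C)(C)C)c(C)c1`) gives 22700 nM, the higher of the two numbers. Compound 3 (`CCn1c(C(=O)OCc2ccc(F)cc2)ccc1C(CC)(CC)c1ccc(OCC(O)C(C)(C)C)c(C)c1`) differs from compound 2 at one place, with 4-fluorobenzyl in place of 4-(2-hydroxyethyl)phenyl on an oxygen next to a carbonyl group. For the measured compounds named here, only one measured step bears on this change, a 16-fold higher number from compound 1 to compound 2 (1.21 log units; beyond the scatter), which is large and beyond the scatter. That step replaced a group with no ring by one holding a six-membered aromatic ring of carbon only, on a carbonyl carbon. The new change instead keeps such a ring on both sides, so the large step offers little guide to its size. Going by the values given here, no measured pair varies the group on this oxygen, and the data give no firm direction. A change no larger than the scatter is therefore expected, with a slight lean towards the lower number of compound 1 at 1400 nM. The estimated step is a 1.3-fold lower number from compound 2 to compound 3 (0.10 log units; within the scatter). For compound 3, the estimated value in this assay is 18000 nM, with an expected range of 6000 nM to 50000 nM.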

Compound 3, half-maximal inhibitory concentration: 14900 nM
Beside the measured number, compound 3's estimate is 1.2-fold (0.08 log units) above it, within the range that was stated.
By their numbers in this assay, from the lowest: compound 1; then compounds 3 and 2 (each within the scatter of the next).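

In this assay, placing 4-fluorobenzyl in place of 4-(2-hydroxyethyl)phenyl on an oxygen next to a carbonyl group gives a 1.5-fold lower number from compound 2 to compound 3 (0.18 log units; within the scatter), so this exchange, the first at this place, does not move the number beyond the scatter, even though the group that leaves has 1 hydrogen-bond donor and 1 hydrogen-bond acceptor and the group that enters has 0 of each. The step of an 11-fold higher number from compound 1 to compound 3 (1.03 log units; beyond the scatter) is beyond the scatter, as is a 16-fold higher number from compound 1 to compound 2 (1.21 log units; beyond the scatter), so the separation from compound 1 holds with either of these two aromatic groups and does not depend on which of them is present. No measurement shown gives a reason for either result.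

The compounds shown leave open whether the separation from compound 1 follows the carboxylic acid of its (1-carboxy-2-methylbutyl)amino group or the nitrogen that joins that group to the carbonyl carbon, which a simple alkylamino group on that carbon would help to separate. They also leave open how a plain benzyl or a 4-(2-hydroxyethyl)benzyl group on the same oxygen would read, which would set the fluorine apart from the hydroxyethyl chain.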